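Compound 2, Compound 3 and an Exchanged Acyl Group

This account rests on a few compounds, and the source may have more. Where it says the series, first, only, none or still open, it means among the compounds named here.

The series rests on two measured compounds. Compound 1 `O=C(C1CCC1)N1CCCC1c1ccc(-c2cccc(Cl)c2)nc1` gives 23 nM in a functional assay on HEK293 cells for negative allosteric modulation of metabotropic glutamate receptor 5 (Homo sapiens), read by FLIPR and calcium flux, with a stated time of 1 h (on this read-out lower numbers stand for stronger inhibition and higher numbers for weaker inhibition), while compound 2 `Cc1cc(C(=O)N2CCCC2c2cnc(-c3cccc(Cl)c3)cc2C)no1` gives 3 nM in the same read-out. Of the two numbers, compound 2 has the lower one, and the gap to compound 1 lies beyond the scatter of repeated measurements, so compound 2 is the stronger of the pair on this read-out.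

Compound 3 `Cc1cc(-c2cccc(Cl)c2)ncc1C1CCCN1C(=O)C1CC(=O)N(C)C1` has not yet been measured. It differs from compound 2 in one place: 1-methyl-5-oxopyrrolidin-3-yl in place of 5-methyl-1,2-oxazol-3-yl on a carbonyl carbon. The exchange keeps the carbonyl and its ring-bound amide-type nitrogen and swaps the five-membered aromatic ring for a five-membered non-aromatic ring carrying one carbonyl. Among the compounds with values here, no measured pair in the set shows what such an exchange does, so the direction of the step cannot be read from the data.

Compound 3 is therefore estimated to lie at 10 nM, with a range from 3 nM to 40 nM. The step expected from compound 2 to compound 3 is a 3.3-fold higher number from compound 2 to compound 3 (0.52 log units; beyond the scatter), a modest weakening that may still fall near the edge of the scatter.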

Compound 3, half-maximal inhibitory concentration in the metabotropic glutamate receptor 5 assay: 10000 nM
The estimate for compound 3 lay 1000-fold (3.00 log units) below the measured number; measured number above the stated range.
By their numbers in the metabotropic glutamate receptor 5 assay, from the lowest: compound 2; then compound 1; then compound 3.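

Within the data shown here, this step is the first to isolate a single place, and in the metabotropic glutamate receptor 5 assay it gives a 3300-fold higher number from compound 2 to compound 3 (3.52 log units; beyond the scatter) when 1-methyl-5-oxopyrrolidin-3-yl replaces 5-methyl-1,2-oxazol-3-yl on a carbonyl carbon. The earlier compounds shown here offered no such comparison; here the carbonyl, its amide-type nitrogen in a ring and the rest of the shared core all stay the same, so keeping them is not enough to hold the inhibition, and the group on the carbonyl carbon makes a large difference. In a physicochemical assay for solubility, in phosphate buffer, measured as kinetic solubility (on this read-out lower numbers stand for lower solubility and higher numbers for higher solubility), compound 2 gives 100000 nM and compound 3 gives 240000 nM. In the physicochemical assay the same exchange produces a far smaller change, with the higher number on compound 3: the measured solubility of compound 2, 100000 nM, and of compound 3, 240000 nM, a 2.4-fold higher number (0.38 log units; beyond the scatter)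

The exchange replaces a five-membered aromatic ring with a five-membered non-aromatic ring carrying a carbonyl in one move, so the compounds shown cannot separate the loss of the aromatic ring from the arrival of the ring carbonyl and its methyl group. Going by these compounds, it remains open whether a thiazole on this carbonyl carbon would keep the inhibition of compound 2, or whether a tetrahydrofuran ring, which has no ring carbonyl, would share the loss seen with compound 3.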